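Amide Variation at the Cinnamoyl End of a Stilbene

This account rests on a few compounds, and the source may have more. Where it says the series, first, only, none or still open, it means among the compounds named here.

Measured compounds in a functional assay on MCF7 cells (Homo sapiens) for inhibition, read by MTT assay, with a stated time of 48 h; a higher number here means a weaker inhibitor, a lower number a stronger inhibitor:
compound 1 `COc1ccc(/C=C/c2cc(OC)cc(OC)c2/C=C/C(=O)N2CCCCC2C)cc1` gives 4350 nM
compound 2 `COc1ccc(/C=C/c2cc(OC)cc(OC)c2/C=C/C(=O)NC(C)C)cc1` gives 2560 nM

Among the measured compounds shown here, only two measurements exist, and they sit close together. For the measured compounds named here, compound 2 stands next to compound 1 rather than apart from it: the single measured step, a 1.7-fold lower number from compound 1 to compound 2 (0.23 log units; within the scatter), lies within the scatter, so the two amides are not separated by these numbers.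

Compound 3 `COc1ccc(/C=C/c2cc(OC)cc(OC)c2/C=C/C(=O)N2CCC(c3ccccc3)CC2)cc1` is the next amide in the series. Compared with compound 2, the change is 4-phenylpiperidin-1-yl in place of isopropylamino on a carbonyl carbon. Going by the values given here, the one measured step that bears on it is the exchange of a cyclic tertiary amide for a secondary amide between compound 1 and compound 2, which produced no change beyond the scatter. The present change returns to a cyclic tertiary amide, now carrying a phenyl group on the ring. Among the compounds with values here, with no step having moved the number by more than the scatter, compound 3 is expected to show at most a modest shift, a 1.4-fold higher number from compound 2 to compound 3 (0.14 log units; within the scatter), in this assay. The estimate for compound 3 is therefore 3500 nM, with a range from 1200 nM to 10000 nM.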

Compound 3, half-maximal inhibitory concentration: 4230 nM
Compound 3: middle estimate off by 1.2-fold (0.08 log units), on the low side; low and high end bracket the measured number.
By their numbers in this assay, from the lowest: compounds 2, 3 and 1 (each within the scatter of the next).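

Replacing isopropylamino with 4-phenylpiperidin-1-yl on the carbonyl carbon swaps a group of 4 heavy atoms, with one hydrogen-bond donor and no ring, for one of 12 heavy atoms, with two six-membered rings and no donor, yet this assay records only a 1.7-fold higher number from compound 2 to compound 3 (0.22 log units; within the scatter) and so does not separate these two amides. Exchanging one cyclic tertiary amide for another, with 4-phenylpiperidin-1-yl in place of 2-methylpiperidin-1-yl, gives a 1.0-fold lower number from compound 1 to compound 3 (0.01 log units; within the scatter) and likewise leaves the two compounds unseparated. All three amides therefore stand within the scatter of one another, and nothing available accounts for this lack of separation.

The compounds shown leave open whether any group at this carbonyl carbon would move the number beyond the scatter, such as 4-methylpiperazin-1-yl, morpholin-4-yl or a longer chain ending in an amine. They also leave open what a carboxylic acid in place of the amide would do, and whether the unsubstituted amide, with two hydrogens on its nitrogen, would stand with these three or apart from them.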